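The compounds below may be only part of what the source reports. "The series", "measured", "known", "first", "only" and "open" are said of these compounds alone.

Compound 2 `c1csc(-c2cn3ccnc3c(-c3ccc4ncn(C5CCCCC5)c4c3)n2)c1` stands lowest of the two numbers in a functional assay on K562 cells (Homo sapiens) for inhibition, read by sulforhodamine B assay, with a stated time of 48 h, tested at 10 uM (a lower number here means less inhibition, a higher number more inhibition at the concentration tested (going by the name of the read-out)), where compound 2 gives 27%. Within the data shown here, compound 1 `c1ccc(-c2cn3ccnc3c(-c3ccc4ncn(C5CCCCC5)c4c3)n2)cc1` gives 70.6% in this assay; the one measured step, a number 43.6 percentage points lower from compound 1 to compound 2 (beyond the scatter), runs the opposite way to the change now considered. Compound 3 `FC(F)(F)c1cccc(-c2cn3ccnc3c(-c3ccc4ncn(C5CCCCC5)c4c3)n2)c1` differs from compound 2 by 3-(trifluoromethyl)phenyl in place of thiophen-2-yl on an aromatic carbon. The return to a six-membered carbon-only ring bears on that measured step, so for compound 3 a rise of comparable size is expected, a number 33 percentage points higher from compound 2 to compound 3 (beyond the scatter). Among the measured compounds shown here, the trifluoromethyl has no counterpart among the measured compounds. Compound 3 is estimated at 60%, range 30% to 85%.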

Compound 3, a percentage reported as inhibition, at one concentration (the size of the read-out at that concentration, not a potency): 21.5%
Compound 3: the middle estimate sits 38.5 percentage points above what was measured, and the stated range ends above it.
By their numbers in this assay, from the lowest: compounds 3 and 2 (each within the scatter of the next); then compound 1.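

In this assay, adding trifluoromethyl to the phenyl ring does not hold the level of compound 1, giving a number 49.1 percentage points lower from compound 1 to compound 3 (beyond the scatter). Replacing thiophen-2-yl with 3-(trifluoromethyl)phenyl gives a number 5.5 percentage points lower from compound 2 to compound 3 (within the scatter), so a six-membered aromatic ring of carbon only does not by itself separate these two compounds. Nothing available explains either step.

As far as these compounds go, whether the drop depends on trifluoromethyl itself or on where it sits on the phenyl ring remains open. From the compounds shown here alone, how a methoxy group, a chlorine atom or an amine on that ring would read also remains open.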